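The compounds below may be only part of what the source reports. "The series", "measured", "known", "first", "only" and "open" are said of these compounds alone.

Working notes on the series.

Among the measured compounds shown here, compound 3 `COc1cc(Cl)cc(-c2nn(-c3cccc(NC(=O)Nc4ccc(Cl)c(C(F)(F)F)c4)c3)cc2-c2ccncc2)c1` stands lowest of the three numbers so far: in a functional assay on NCI-H226 cells (Homo sapiens) for inhibition, read by sulforhodamine B assay, with a stated time of 48 h, tested at 10 uM (on this read-out lower numbers stand for a stronger effect and higher numbers for a weaker effect at the one concentration tested), compound 3 gives -2.82%. Its nearest neighbour is compound 2 `O=C(Nc1cccc(-n2cc(-c3ccncc3)c(-c3cc(O)cc(Cl)c3)n2)c1)Nc1ccc(Cl)c(Cl)c1`, which in this assay gives 14.5%, and the furthest is compound 1 `COc1cc(Cl)cc(-c2nn(-c3cccc(NC(=O)c4ccc(Cl)c(Cl)c4)c3)cc2-c2ccncc2)c1`, which in this assay gives 66.3%.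

The next compound, compound 4 `COc1cc(Cl)cc(-c2nn(-c3cccc(NC(=O)Nc4ccc(Cl)c(Cl)c4)c3)cc2-c2ccncc2)c1`, differs from compound 3 in one place: chloro in place of trifluoromethyl on an aromatic carbon. For the measured compounds named here, only one measured step touches this pair of groups, a number 69.1 percentage points lower from compound 1 to compound 3 (beyond the scatter), but there the urea also replaced the amide, so the change from 3,4-dichlorophenyl to 4-chloro-3-(trifluoromethyl)phenyl alone cannot be read off from that step. Going by the values given here, compound 2 carries the same (3,4-dichlorophenyl)amino urea as compound 4 and sits not far from compound 3, though it differs from compound 4 elsewhere and no step is given for that pair. Taken together, a small rise in this assay from compound 3 to compound 4 is expected, near the scatter: a number 10.8 percentage points higher from compound 3 to compound 4 (beyond the scatter). The estimate for compound 4 in this assay is 8%, within -12% to 32%.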

Compound 4, a percentage reported as activity, at one concentration (the size of the read-out at that concentration, not a potency): 7.27%
Beside the measured number, compound 4's estimate is 0.7 percentage points above it; the range from low to high includes it.
By their numbers in this assay, from the lowest: compound 3; then compounds 4 and 2 (each within the scatter of the next); then compound 1.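

With the urea now paired with the same 3,4-dichlorophenyl group as the amide, the linker change can be read apart from the aryl change: in this assay, a number 59 percentage points lower from compound 1 to compound 4 (beyond the scatter) when (3,4-dichlorophenyl)amino replaces 3,4-dichlorophenyl on the carbonyl carbon. The aryl change alone is much smaller, as a number 10.1 percentage points higher from compound 3 to compound 4 (beyond the scatter) with chloro in place of trifluoromethyl on the aromatic carbon ortho to a chloro group, so both groups give low numbers on the urea, with trifluoromethyl the lower of the pair. On the oxygen, a number 7.2 percentage points lower from compound 2 to compound 4 (within the scatter) with methyl in place of hydrogen, so this change does not separate the two compounds in this read-out.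

Still open, on these data alone, is how a bromo, a methyl or a nitrile would read on that aromatic carbon, and how a longer chain would read on the oxygen. Nothing at hand explains any of these steps.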